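The source may hold more compounds than are shown below. What is called first, only, known or untested is meant among the compounds shown, and "the series" means these compounds.

Three compounds share one core and differ only in the aryl group attached at one aromatic carbon. Compound 1 `CCCCCCC(Sc1nc(Cl)cc(Nc2nc(-c3ccc(C)cc3)cs2)n1)C(=O)O` gives 200 nM in an assay for inhibition of Polyunsaturated fatty acid 5-lipoxygenase (Homo sapiens), read by HPLC, with stated times of 15 min and 10 min; on this read-out higher numbers stand for weaker inhibition and lower numbers for stronger inhibition. Compound 2 `CCCCCCC(Sc1nc(Cl)cc(Nc2nc(-c3cccc4ccccc34)cs2)n1)C(=O)O` gives 400 nM in this assay, and compound 3 `CCCCCCC(Sc1nc(Cl)cc(Nc2nc(-c3ccc(F)cc3F)cs2)n1)C(=O)O` gives 1500 nM in this assay, the highest of the three numbers. The steps of a 7.5-fold higher number from compound 1 to compound 3 (0.88 log units; beyond the scatter) and a 3.8-fold higher number from compound 2 to compound 3 (0.57 log units; beyond the scatter) are both modest and beyond the scatter, whereas a 2.0-fold higher number from compound 1 to compound 2 (0.30 log units; within the scatter) lies within it. Compound 4 `CCCCCCC(Sc1nc(Cl)cc(Nc2nc(-c3ccc([N+](=O)[O-])cc3)cs2)n1)C(=O)O` differs from compound 3 by 4-nitrophenyl in place of 2,4-difluorophenyl on an aromatic carbon. Within the data shown here, no measured step involves a nitro group, so the measured steps show only that exchanging the aryl group at this carbon has shifted the number by amounts from within the scatter up to modest. The step from compound 3 is therefore expected to be a 2.1-fold lower number from compound 3 to compound 4 (0.33 log units; beyond the scatter), moving back toward the other two compounds without clearly passing them. Compound 4 is estimated at 700 nM in this assay, with a range from 200 nM to 2500 nM.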

Compound 4, half-maximal inhibitory concentration: 1400 nM
Estimate against measurement, compound 4: 2.0-fold (0.30 log units) below, and the stated range covers the measured number.
By their numbers in this assay, from the lowest: compounds 1 and 2 (each within the scatter of the next); then compounds 4 and 3 (each within the scatter of the next).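

Within this assay the step of a 1.1-fold lower number from compound 3 to compound 4 (0.03 log units; within the scatter) lies within the scatter, so at this aromatic carbon a phenyl ring bearing a nitro group and one bearing two fluorines give numbers that cannot be told apart. The steps of a 3.5-fold higher number from compound 2 to compound 4 (0.54 log units; beyond the scatter) and a 7.0-fold higher number from compound 1 to compound 4 (0.85 log units; beyond the scatter) are both modest and beyond the scatter, which places compound 4 with compound 3 and divides the four compounds into two pairs, the naphthalen-1-yl and 4-methylphenyl compounds on the lower side. No available evidence bears on why these aryl groups fall into these two pairs.

The compounds shown leave open whether an amine, a carboxylic acid or a methoxy group in place of the nitro group would fall with compound 1 or with compound 4. They also leave open whether a single fluorine would give the same number as the two fluorines of compound 3.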